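Series notes: from compound 1 toward compound 4

The source may report more compounds than this note shows. Statements on the series, on what has been measured and on what is new or still open speak of the compounds shown alone.

Compound 1 `NCCNc1c(C(=O)NCc2ccc(F)cc2)nc(Br)c2cccnc12` stands in a functional assay on HCT-116 cells (Homo sapiens) for cytotoxicity, read by MTT assay, with a stated time of 72 h (on this read-out higher numbers stand for weaker inhibition and lower numbers for stronger inhibition), at > 20000 nM; this is a limit of the assay, not a number, and it is the same point as the limit of > 20000 nM in this assay, at which 1 of the 3 values shown sits. Compound 2 `C[C@H](CO)Nc1nc(C(=O)NCc2ccc(F)cc2)c(O)c2ncccc12` carries no result in this assay, recorded as "not determined" (no result reported). For the measured compounds named here, compound 3 `O=CNCCCCCCNc1nc(C(=O)NCc2ccc(F)cc2)c(O)c2ncccc12` gives 6000 nM in this assay and is the only compound of the set with a numbered value. Compound 1 therefore sits at the weak end of what this assay reports, with no single number of its own. Going by the values given here, no pair of measured compounds differs in a single place, so no measured step is available within the set.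

Compound 4 `O=C(NCc1ccc(F)cc1)c1nc(Br)c2cccnc2c1NCc1ccc(F)cc1` is the unmeasured analogue and differs from compound 1 by 4-fluorophenyl in place of aminomethyl on a saturated chain carbon bound to a nitrogen on an aromatic ring. With compound 1 known only as a limit, the starting point for this step is itself open. The step from compound 1 to compound 4 is expected to be an at least 1.3-fold lower number from compound 1 to compound 4 (0.12 log units; that floor lies within the scatter), a modest move toward stronger inhibition rather than none, but with a fair chance that this assay again reports only a limit. Compound 4 is accordingly estimated at 15000 nM in this assay, within a range from 4000 nM to 60000 nM.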

Compound 4, half-maximal inhibitory concentration: > 20000 nM
Compound 4 gave a limit, no number (the forecaster's own chance of this, stated with the estimate: 45%); middle value at least 1.3-fold (0.12 log units) away from the limit.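

In this assay compound 4 gives > 20000 nM, a limit of the assay and not a number. Compound 1 also stands only as a limit, so no step can be read between compound 1 and compound 4: the limit of > 20000 nM in this assay, at which 2 of the 4 values shown sit.

Whether 4-fluorophenyl in place of aminomethyl shifts the read-out at all, and in which direction, remains open with the compounds shown.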